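Compound 2 to compound 3: replacing pyridin-4-yl

The compounds below may be only part of what the source reports. "The series", "measured", "known", "first", "only" and "open" are said of these compounds alone.

Of the compounds shown here, two sharing one core have been measured so far. In a physicochemical assay for lipophilicity, measured as octanol-water partition (on this read-out lower numbers stand for lower lipophilicity and higher numbers for higher lipophilicity), compound 1 `O=C(NNc1ccnc2cc(Cl)ccc12)c1ccccc1/N=C/c1ccc(Cl)cc1Cl` gives 6.22, and compound 2 `O=C(NNc1ccnc2cc(Cl)ccc12)c1ccccc1/N=C/c1ccncc1` gives 3.86, the lower of the two numbers.

The next structure is compound 3 `O=C(NNc1ccnc2cc(Cl)ccc12)c1ccccc1/N=C/c1cc2ccccc2nc1Cl`, which has 2-chloroquinolin-3-yl in place of pyridin-4-yl on a carbon with a double bond to nitrogen.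

Among the measured compounds shown here, only one measured step bears on this change: a number 2.36 log units lower from compound 1 to compound 2 (beyond the scatter). That step is large and beyond the scatter, and it brought pyridin-4-yl in place of 2,4-dichlorophenyl at the same place. Here pyridin-4-yl leaves instead, and the entering group also holds chlorine, so the earlier step is read in the opposite direction as a rough guide. For the measured compounds named here, no measured compound carries 2-chloroquinolin-3-yl, and a single step is thin support, so the range is kept wide.

A large upward move in this assay is expected, of similar size to the measured step, with an estimated a number 2.04 log units higher from compound 2 to compound 3 (beyond the scatter). Compound 3 is expected at 5.9, with an estimated range of 5.2 to 6.6.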

Compound 3, partition coefficient: 6
For compound 3 the middle estimate is 0.10 log units below the measured one, and the stated range covers the measured number.
By their numbers in this assay, from the lowest: compound 2; then compounds 3 and 1 (each within the scatter of the next).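

At the place on a carbon with a double bond to nitrogen, this assay now shows a second large step (a number 2.14 log units higher from compound 2 to compound 3 (beyond the scatter)), so 2-chloroquinolin-3-yl in place of pyridin-4-yl carries the read-out back up the range that the earlier step had covered downward. The comparison with the dichlorinated compound (a number 0.22 log units lower from compound 1 to compound 3 (within the scatter)) lies within the scatter, so 2-chloroquinolin-3-yl and 2,4-dichlorophenyl cannot be told apart at this place, even though 2-chloroquinolin-3-yl holds an aromatic ring with 1 hetero atom, as pyridin-4-yl does; a ring nitrogen in the group therefore does not by itself place a compound with compound 2. No supporting measurement is available to account for either step.

As far as these compounds go, the change to compound 3 brings the second ring and the chlorine together, so their separate contributions stay open, and an unchlorinated quinolin-3-yl at the same place would divide them. Also open is how this place responds to a group of a different kind, such as an amine or a carboxylic acid, since every group shown here is aromatic.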